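From Phenyl to Pyridin-3-yl in an Antiproliferative Series

The source may report more compounds than this note shows. Statements on the series, on what has been measured and on what is new or still open speak of the compounds shown alone.

In a functional assay on A-375 cells (Homo sapiens) for antiproliferative activity (on this read-out lower numbers stand for stronger inhibition and higher numbers for weaker inhibition), compound 1 `O=C(Nc1ccc2scnc2c1)C1CCCN(Cc2ccc(F)c(F)c2)C1` gives > 20000 nM as a limit and not a number. In this assay compound 2 `O=C(Nc1ccc(-c2cscn2)cc1)C1CCCN(Cc2ccccc2F)C1` gives 4000 nM and compound 3 `O=C(Nc1ccc(-c2ccccc2)cc1)C1CCCN(Cc2ccc(F)c(F)c2)C1` gives 2580 nM as measured numbers. Compound 3 thus stands within the scatter of compound 2, its nearest neighbour on the numbers. Compound 4 `O=C(Nc1ccc(-c2cccnc2)cc1)C1CCCN(Cc2ccc(F)c(F)c2)C1` carries pyridin-3-yl in place of phenyl on an aromatic carbon and awaits measurement. Going by the values given here, no measured pair here differs in one place only, so the expected step of a 1.4-fold higher number from compound 3 to compound 4 (0.13 log units; within the scatter) is small, leaning slightly toward weaker inhibition and not beyond the scatter. For compound 4 the estimated value is 3500 nM with an expected range from 1200 nM to 11000 nM in this assay when tested.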

Compound 4, half-maximal inhibitory concentration: 610 nM
Compound 4: the middle estimate sits 5.7-fold (0.76 log units) above what was measured; the whole stated range lies above it.
By their numbers in this assay, from the lowest: compound 4; then compounds 3 and 2 (each within the scatter of the next). At a limit, above all of these: compound 1.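

In this assay, pyridin-3-yl in place of phenyl on an aromatic carbon, para to a large group, gives a 4.2-fold lower number from compound 3 to compound 4 (0.63 log units; beyond the scatter), the only step shown at a single place, and it lies beyond the scatter. This position is therefore sensitive to the exchange of one ring carbon for a nitrogen, even though the heavy-atom count stays the same. Nothing measured here explains why this step occurs.

On these data alone, whether an amine, a carboxylic acid or a methoxy group on this ring would give a lower or higher number stays open. Going by these compounds alone, it also stays open whether the step would hold on a different benzyl substituent, such as the one in compound 2.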